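A pyrazole in place of a sulfonamide on the shared core

The source may report more compounds than this note shows. Statements on the series, on what has been measured and on what is new or still open speak of the compounds shown alone.

The set consists of three measured compounds and one that awaits testing, all examined in a functional assay on CHO cells for agonist activity at Alpha-1D adrenergic receptor (Homo sapiens), read by FLIPR and calcium flux; on this read-out lower numbers stand for an effect already at smaller amounts and higher numbers for an effect only at larger amounts of compound. Compound 1 `CS(=O)(=O)Nc1cccc2c1CCC2c1ncc[nH]1` gives a value that is only a limit of the assay, > 10000 nM. Compound 2 `Cc1c(OCC2=NCCN2)ccc(Cl)c1NS(C)(=O)=O` likewise gives only a limit in this assay, > 10000 nM. Compound 3 `CCS(=O)(=O)Nc1cccc2c1CCC2c1ncc[nH]1` also stands at a limit in this assay, > 10000 nM. Within the data shown here, the one single-site step among them, a step that the two limits leave unreadable from compound 1 to compound 3, therefore cannot be read, since the limit of > 10000 nM in this assay, at which 3 of the 3 values shown sit, holds both ends of it.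

Compound 4 `Cc1n[nH]cc1-c1cccc2c1CCC2c1ncc[nH]1` differs from compound 3 by 3-methyl-1H-pyrazol-4-yl in place of (ethylsulfonyl)amino on an aromatic carbon. Among the measured compounds shown here, no measured step bears on such a change: the only recorded step is unreadable, and nothing in the data connects a pyrazole replacement for a sulfonamide to a change in this assay. The expectation is therefore that compound 4 remains near the limit, with an estimated step that the limit leaves unreadable from compound 3 to compound 4 from compound 3. Compound 4 is estimated at 15000 nM, within a range from 2000 nM to 60000 nM.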

Compound 4, half-maximal effective concentration: 634 nM
Compound 4: the middle estimate sits 24-fold (1.37 log units) above what was measured; the measured number lies below the stated range.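

Putting 3-methyl-1H-pyrazol-4-yl on this aromatic carbon gives the only response in this assay that reads as a number rather than a limit: the limit of > 10000 nM in this assay, at which 3 of the 4 values shown sit. Starting from the (ethylsulfonyl)amino group, the change is an at least 15-fold lower number from compound 3 to compound 4 (1.19 log units; beyond the scatter), and starting from the methanesulfonamido group, it is an at least 15-fold lower number from compound 1 to compound 4 (1.19 log units; beyond the scatter). So the group on this carbon can move the read-out well beyond the scatter, while the step between the two sulfonamide compounds cannot be read, and the true size of both new steps may be larger than printed.

Going by these compounds, it remains open whether the pyrazole ring or its methyl accounts for the shift, and how an unsubstituted 1H-pyrazol-4-yl, an amine or a carboxylic acid on the same carbon would read. Compound 2 differs from the others in more than one place, so it offers no direct comparison.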